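A few compounds are considered here, and "the series" means these few. Any claim that something is new, unique, unknown or untested is made for them only; others in the source may bear on it.

Measured compounds:

Compound 1 `O=C1COc2ccc(-c3cccc(NS(=O)(=O)c4ccc(F)cc4)c3)cc2N1c1ccccc1`: in a functional assay on A549 cells (Homo sapiens) for antiproliferative activity, read by MTT assay, with a stated time of 72 h (a higher number here means a weaker inhibitor, a lower number a stronger inhibitor), compound 1 reaches only the limit > 40000 nM.
Compound 2 `O=C1COc2ccc(-c3cnc(Cl)c(NS(=O)(=O)c4ccc(F)cc4)c3)cc2N1c1ccccc1`: in this assay compound 2 gives 14700 nM.
Compound 3 `O=C1COc2ccc(-c3cccc(NS(=O)(=O)c4ccc(F)cc4)c3)cc2N1C1CC1`: in this assay compound 3 reaches only the limit > 40000 nM.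

Compound 3 differs from compound 1 by cyclopropyl in place of phenyl on an amide-type nitrogen in a ring. The step that the two limits leave unreadable from compound 1 to compound 3 cannot be read, since both ends sit at the limit of > 40000 nM in this assay, at which 2 of the 3 values shown sit. The difference between the cores of compound 1 and compound 2 is not broken down here; compound 2 is the only one of the three with a number rather than a limit.

Compound 4 `O=C1COc2ccc(-c3cnc(Cl)c(NS(=O)(=O)c4ccc(F)cc4)c3)cc2N1C1CC1` is not yet measured. It differs from compound 2 by cyclopropyl in place of phenyl on an amide-type nitrogen in a ring, the same change as from compound 1 to compound 3. The measured pair gives no readable size for this change, so the step of a 1.4-fold higher number from compound 2 to compound 4 (0.13 log units; within the scatter) is expected to stay small. Compound 4 is expected to give about 20000 nM in this assay, between 8000 nM and 40000 nM, with a fair chance that only a limit is reported.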

Compound 4, half-maximal inhibitory concentration: 4330 nM
Beside the measured number, compound 4's estimate is 4.6-fold (0.66 log units) above it, outside the stated range (below it).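

In this assay, cyclopropyl in place of phenyl on an amide-type nitrogen in a ring gives a 3.4-fold lower number from compound 2 to compound 4 (0.53 log units; beyond the scatter), a modest gain on this core. On the core of compound 1, the same change cannot be read, since compound 1 and compound 3 each reach only a limit, not a number: the limit of > 40000 nM in this assay, at which 2 of the 4 values shown sit. Carrying the change from one core to another is thus neither confirmed nor refuted, as any gain on the core of compound 1 could lie hidden beyond that limit, and one readable pair sets no trend.

Open, going by these compounds, is whether the gain is particular to cyclopropyl or extends to other groups on that nitrogen, such as methyl, isopropyl or a longer chain ending in an amine.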